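Aryl amide replacement across a shared core

The source may hold more compounds than are shown below. What is called first, only, known or untested is meant among the compounds shown, and "the series" means these compounds.

Measured so far:
compound 1 `Cc1cc(C(=O)NCN2CCC(c3cccc[n+]3[O-])CC2)ccc1F` — 67%
compound 2 `Cc1cc(C)cc(NC(=O)CN2CCC(c3cccc[n+]3[O-])CC2)c1` — 76%

Both compounds were read in a functional assay on HEK293 cells for agonist activity at D(4) dopamine receptor (Homo sapiens), read by FLIPR; on this read-out lower numbers stand for smaller maximal responses and higher numbers for larger maximal responses. Compound 1 gives 67% and compound 2 gives 76%. Compound 2 shows the larger of the two numbers, but the gap to compound 1 lies within the usual scatter of repeated measurements, so the two cannot be told apart on this read-out and neither is called the more efficacious.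

Compound 3 `O=C(CN1CCC(c2cccc[n+]2[O-])CC1)Nc1ccc(F)cc1` has not yet been measured in this assay. It differs from compound 2 in one place: 4-fluorophenyl in place of 3,5-dimethylphenyl on an amide-type nitrogen. For the measured compounds named here, no step between two measured compounds exists for a change of this kind, and the only other measured compound, compound 1, sits within the scatter of compound 2. There is therefore nothing in the numbers to suggest a shift in either direction. The expected step is a number 6 percentage points lower from compound 2 to compound 3 (within the scatter), that is, none beyond the scatter. Compound 3 is estimated at 70%, with a range from 55% to 85%.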

Compound 3, largest response reached (reported as efficacy), in percent of the reference or control that the assay uses: 71%
For compound 3 the middle estimate is 1 percentage points below the measured one; the measured number falls inside the stated range.
By their numbers in this assay, from the lowest: compounds 1, 3 and 2 (each within the scatter of the next).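

In this assay, for the compounds shown here, 4-fluorophenyl in place of 3,5-dimethylphenyl on an amide-type nitrogen gives a number 5 percentage points lower from compound 2 to compound 3 (within the scatter), the first step read between two compounds that differ in one place. For this pair, the two methyl groups and the carbon-bound hydrogen at the fourth ring position can thus give way to a single fluorine on the phenyl ring, with no difference on this read-out that can be told from the scatter. Nothing available bears on the reason for this result.

The compounds shown leave open whether this insensitivity extends beyond substituted phenyl groups on the amide-type nitrogen, for instance to a saturated cyclohexyl ring, a pyridyl ring or a phenyl ring carrying a carboxylic acid. They also leave open whether a longer chain between the amide-type nitrogen and the aromatic ring would give a step beyond the scatter, and whether the same replacement would read alike on a different core.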